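This account rests on a few compounds, and the source may have more. Where it says the series, first, only, none or still open, it means among the compounds named here.

Of the compounds shown here, two built on one shared core have been measured in a functional assay on A549 cells (Homo sapiens) for cytotoxicity, read by sulforhodamine B assay; a higher number here means a weaker inhibitor, a lower number a stronger inhibitor. Compound 1 `C=C1[C@@H](OC(C)=O)C[C@@H]2[C@](C)(COC=O)[C@H](OC(C)=O)CC[C@@]2(C)[C@@H]1C[C@@H](Nc1ccc(O)cc1)C1=CCOC1=O` carries a (4-hydroxyphenyl)amino group; in this assay compound 1 gives 29100 nM, the higher of the two numbers recorded so far. Going by the values given here, compound 2 `C=C1[C@@H](OC(C)=O)C[C@@H]2[C@](C)(CO[Si](C)(C)C(C)(C)C)[C@H](OC(C)=O)CC[C@@]2(C)[C@@H]1C[C@@H](Nc1cccc(F)c1)C1=CCOC1=O` differs from compound 1 in more than one place, so no single step can be drawn between the two; in this assay compound 2 gives 4060 nM, a lower number than that of compound 1 by a margin beyond the usual scatter.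

Compound 3 `C=C1[C@@H](OC(C)=O)C[C@@H]2[C@](C)(COC=O)[C@H](OC(C)=O)CC[C@@]2(C)[C@@H]1C[C@@H](Nc1ccc(F)cc1)C1=CCOC1=O` is compound 1 with a single alteration: fluoro in place of hydroxy on an aromatic carbon. Among the compounds with values here, no measured pair shows this exact change on this core. Compound 2 does carry a fluoro group on its aromatic ring and reaches 4060 nM, but it also differs elsewhere, so its number cannot be credited to the fluoro group alone. A modest step toward a lower number is nonetheless expected, a 2.1-fold lower number from compound 1 to compound 3 (0.32 log units; beyond the scatter), though on thin footing. Compound 3 is therefore estimated at 14000 nM, with a plausible range from 5000 nM to 40000 nM.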

Compound 3, half-maximal inhibitory concentration: 21300 nM
Compound 3: the middle estimate sits 1.5-fold (0.18 log units) below what was measured; the measured number falls inside the stated range.
By their numbers in this assay, from the lowest: compound 2; then compounds 3 and 1 (each within the scatter of the next).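

Exchanging hydroxy for fluoro on the aromatic carbon para to a large group gives a 1.4-fold lower number from compound 1 to compound 3 (0.14 log units; within the scatter) in this assay and so no change that can be told apart from repeat measurement. Going by these compounds alone, this is the first single-place comparison on the shared core, and it shows that at this position the number holds whether the group carries 1 hydrogen-bond donor and 1 hydrogen-bond acceptor, as hydroxy does, or neither, as fluoro does. Nothing further has been measured that could say why the two groups read alike.

An amine, a carboxylic acid, a methoxy group or a longer chain at this same position could still move the number in either direction, so the step speaks for hydroxy and fluoro alone. The finding also rests on one pair of compounds, and the compounds shown do not tell whether the same exchange would read alike with a different group elsewhere on the shared core.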